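Flipping a Double Bond in an Inactive Pair

The source may report more compounds than this note shows. Statements on the series, on what has been measured and on what is new or still open speak of the compounds shown alone.

Compound 1 `O=C(/C=C/c1ccc(O)cc1)O[C@H]1[C@H](O[C@@H]2CCCC[C@H]2O)O[C@H](CO)[C@@H](O)[C@@H]1O`: > 10000 nM in a functional assay on SK-MEL-2 cells (Homo sapiens) for cytotoxicity, read by sulforhodamine B assay; on this read-out lower numbers stand for stronger inhibition and higher numbers for weaker inhibition
Compound 2 `O=C(/C=C/c1ccc(O)cc1)O[C@H]1[C@H](O[C@H]2CCCC[C@H]2O)O[C@H](CO)[C@@H](O)[C@@H]1O`: > 10000 nM in this assay

Compound 1 reaches only the limit > 10000 nM in this assay. Compound 2 likewise stops at the limit > 10000 nM in this assay. The step that the two limits leave unreadable from compound 1 to compound 2 cannot be read because of the limit of > 10000 nM in this assay, at which 2 of the 2 values shown sit, although (the fact that compounds 1 and 2 differ only in the configuration as drawn).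

Compound 3 `O=C(/C=C\c1ccc(O)cc1)O[C@H]1[C@H](O[C@H]2CCCC[C@H]2O)O[C@H](CO)[C@@H](O)[C@@H]1O` differs from compound 2 in that (the two compounds have the same atoms and bonds and differ only in configuration as drawn: 1 of 8 stereo elements differ; a double bond is drawn E in compound 2 and Z in compound 3). Among the measured compounds shown here, no measured step bears on such a change, and both values so far are limits, so nothing beyond the scatter is expected in this assay. Compound 3 is expected to give 15000 nM, within 5000 nM to 50000 nM, most likely again as a limit. The step that the limit leaves unreadable from compound 2 to compound 3 is expected to be small.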

Compound 3, half-maximal inhibitory concentration: > 10000 nM
Compound 3: no number, only a limit (the forecaster's own chance of this, stated with the estimate: 85%); the middle value does not contradict the limit.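

In this assay, among the compounds shown here, compound 3 gives only the limit > 10000 nM and no number, so no step among compound 1, compound 2 and compound 3 can be read. From the compounds shown here alone, whether the configuration at the saturated ring carbon or at the double bond affects cytotoxicity stays open.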